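A few compounds are considered here, and "the series" means these few. Any claim that something is new, unique, unknown or untested is made for them only; others in the source may bear on it.

Three compounds sharing one core were tested in an ADME assay on HUVEC cells (Homo sapiens) for cytotoxicity, read by MTT assay, with a stated time of 72 h; a higher number here means a weaker inhibitor, a lower number a stronger inhibitor. Compound 1 `O=C(O)CCC(=O)OCCCCCCSc1ccc([N+](=O)[O-])c2nonc12`, whose chain ends in a free acid, gives 740 nM. Compound 2 `O=C(CCC(=O)OCCCCCCSc1ccc([N+](=O)[O-])c2nonc12)Nc1ccccc1Cl` carries a (2-chlorophenyl)amino group on that carbonyl carbon and gives 2950 nM, the highest number of the three. Compound 3 `Cc1ccccc1NC(=O)CCC(=O)OCCCCCCSc1ccc([N+](=O)[O-])c2nonc12` carries a (2-methylphenyl)amino group there and gives 1410 nM. The step of a 4.0-fold higher number from compound 1 to compound 2 (0.60 log units; beyond the scatter) is modest, the step of a 1.9-fold higher number from compound 1 to compound 3 (0.28 log units; within the scatter) stays within the scatter, and the step of a 2.1-fold lower number from compound 2 to compound 3 (0.32 log units; beyond the scatter) is modest.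

Compound 4 `COc1ccccc1NC(=O)CCC(=O)OCCCCCCSc1ccc([N+](=O)[O-])c2nonc12` differs from compound 2 by methoxy in place of chloro on an aromatic carbon. For the measured compounds named here, the only measured step that bears on this change is the swap of the same chloro for methyl, which gave a modest lowering in this assay and suggests that replacing the chloro tends to bring the number down somewhat, with no other data on methoxy. A modest lowering, or possibly no change beyond the scatter, is therefore expected for compound 4 in this assay, a step of a 1.6-fold lower number from compound 2 to compound 4 (0.21 log units; within the scatter). Compound 4 is estimated at 1800 nM, with a range from 900 nM to 4500 nM.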

Compound 4, half-maximal inhibitory concentration: 1610 nM
The estimate for compound 4 lay 1.1-fold (0.05 log units) above the measured number, within the range that was stated.
By their numbers in this assay, from the lowest: compounds 1, 3, 4 and 2 (each within the scatter of the next, the first and the last beyond it).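

In this assay methoxy in place of chloro on this aromatic carbon, ortho to a large group, gives a 1.8-fold lower number from compound 2 to compound 4 (0.26 log units; within the scatter) and stays within the scatter, and methoxy in place of methyl gives a 1.1-fold higher number from compound 3 to compound 4 (0.06 log units; within the scatter) and stays within it too. Methoxy and methyl therefore cannot be told apart at this position, even though the step from chloro to methyl just passed the scatter. Set against the free acid of compound 1, the (2-methoxyphenyl)amino group gives a 2.2-fold higher number from compound 1 to compound 4 (0.34 log units; beyond the scatter) and lies beyond the scatter, as the (2-chlorophenyl)amino group of compound 2 does, while the (2-methylphenyl)amino group of compound 3 does not.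

Open, on these data alone, is where a hydroxy group, an amine or a fluorine on this same carbon would fall relative to these compounds. Nothing measured here gives a reason for these numbers.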